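The source may hold more compounds than are shown below. What is called first, only, known or untested is meant among the compounds shown, and "the series" means these compounds.

Measured so far:
- compound 1 `Cc1c(OCCCCOCOc2ccc(C(=O)O)cc2)ccc(C(=O)CC2CCCC2)c1O`: 1910 nM
- compound 2 `Cc1c(OCCCCOc2ccc(C(=O)O)cc2Cl)ccc(C(=O)CC2CCCC2)c1O`: > 10000 nM

In an assay on HEK293 cells for positive allosteric modulation of metabotropic glutamate receptor 3 (Rattus norvegicus), read by thallium flux, with a stated time of 2.5 min (on this read-out lower numbers stand for an effect already at smaller amounts and higher numbers for an effect only at larger amounts of compound), compound 1 gives 1910 nM. For compound 2 the result in this assay is only a limit of the assay, > 10000 nM, so no exact number is known; compound 2 thus sits at the weak end of the two values shown, consistent with the limit of > 10000 nM in this assay, at which 1 of the 2 values shown sits. Among the compounds with values here, the one measured step, an at least 5.2-fold higher number from compound 1 to compound 2 (0.71 log units; beyond the scatter), shows that moving from the (4-carboxyphenoxy)methyl group to the 4-carboxy-2-chlorophenyl group lost activity.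

Compound 3 `Cc1c(OCCCCOc2cccc(C(=O)O)c2)ccc(C(=O)CC2CCCC2)c1O` differs from compound 2 by 3-carboxyphenyl in place of 4-carboxy-2-chlorophenyl on an oxygen on a saturated carbon. Within the data shown here, no measured step covers this particular exchange, so the direction is uncertain; the only guidance is that a carboxyphenyl attached through an extra oxygen-methylene unit, as in compound 1, gave a measurable number. Compound 3 is therefore expected to stay near the limit, with the step of an at least 1.1-fold lower number from compound 2 to compound 3 (0.04 log units; that floor lies within the scatter) as the estimate. The expected value for compound 3 in this assay is 9000 nM, within a range of 2000 nM to 40000 nM.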

Compound 3, half-maximal effective concentration: 3400 nM
The estimate for compound 3 lay 2.6-fold (0.42 log units) above the measured number, within the range that was stated.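

In this assay, the exchange on this oxygen gives an at least 2.9-fold lower number from compound 2 to compound 3 (0.46 log units; beyond the scatter), so a carboxyphenyl group attached directly to the oxygen can give a measurable number, which compound 2 did not show. Compound 2 itself remains a limit of the assay: the limit of > 10000 nM in this assay, at which 1 of the 3 values shown sits.

Replacing the (4-carboxyphenoxy)methyl group gives a 1.8-fold higher number from compound 1 to compound 3 (0.25 log units; within the scatter), so the 3-carboxyphenyl group and that group cannot be told apart here, and a measurable number does not depend on the latter.

The step from the 4-carboxy-2-chlorophenyl group removes the chlorine and changes the number in the group's name at once, so the compounds shown cannot say which of the two matters. A 4-carboxyphenyl group without chlorine would separate them, and a tetrazole in place of the carboxylic acid remains an open question.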